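The source may hold more compounds than are shown below. What is called first, only, known or untested is meant among the compounds shown, and "the series" means these compounds.

Measured compounds:
compound 1, `CC(O)(CSc1ccc(C(F)(F)F)cc1)C(=O)Nc1ccc(S(F)(F)(F)(F)F)cc1`, which in a functional assay on DU-145 cells (Homo sapiens) for antiproliferative activity, read by propidium iodide staining, with a stated time of 96 h (a lower number here means a stronger inhibitor, a higher number a weaker inhibitor), gives 28800 nM;
compound 2, `CC(O)(CSc1ccccc1C(F)(F)F)C(=O)Nc1ccc(S(F)(F)(F)(F)F)cc1`, which in this assay gives 15800 nM;
compound 3, `CC(O)(CSc1ccc(OC(F)(F)F)cc1)C(=O)Nc1ccc(S(F)(F)(F)(F)F)cc1`, which in this assay gives 12500 nM.

All three share a core and differ only in the aryl group on the sulfur. Compound 2 differs from compound 1 by 2-(trifluoromethyl)phenyl in place of 4-(trifluoromethyl)phenyl on a sulfur; the corresponding step is a 1.8-fold lower number from compound 1 to compound 2 (0.26 log units; within the scatter). Compound 3 differs from compound 1 by trifluoromethoxy in place of trifluoromethyl on an aromatic carbon; here the step is a 2.3-fold lower number from compound 1 to compound 3 (0.36 log units; beyond the scatter). The values of compound 2 and compound 3 lie within the scatter of each other, so nothing can be said about their order.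

Compound 4, `CC(O)(CSc1ccccc1OC(F)(F)F)C(=O)Nc1ccc(S(F)(F)(F)(F)F)cc1`, has not yet been measured in this assay. It differs from compound 2 by trifluoromethoxy in place of trifluoromethyl on an aromatic carbon. This is the same kind of change as from compound 1 to compound 3, but not the same: in compound 3 the trifluoromethoxy stands para to a large group, whereas in compound 4 it stands ortho to a large group. Resting on the step of a 2.3-fold lower number from compound 1 to compound 3 (0.36 log units; beyond the scatter) from compound 1 to compound 3, a modest step of similar direction is expected from compound 2 to compound 4, estimated as a 2.0-fold lower number from compound 2 to compound 4 (0.30 log units; within the scatter), though the different place leaves it uncertain whether the step will carry over in full. Compound 4 is therefore expected to give about 8000 nM, with a plausible range from 3500 nM to 18000 nM.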

Compound 4, half-maximal inhibitory concentration: 29000 nM
Compound 4: middle estimate off by 3.6-fold (0.56 log units), on the low side; the measured number lies above the stated range.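

In this assay, placing trifluoromethoxy in place of trifluoromethyl on the core of compound 2 gives a 1.8-fold higher number from compound 2 to compound 4 (0.26 log units; within the scatter), so compound 2 and compound 4 cannot be put in any order. The same exchange therefore does not carry over with its size intact from the core of compound 1 to that of compound 2, and a step read on one of these aryl groups cannot simply be transferred to the other: the same change on two cores in this assay, a 2.3-fold lower number (0.36 log units; beyond the scatter) from compound 1 to compound 3 and a 1.8-fold higher number (0.26 log units; within the scatter) from compound 2 to compound 4, 4.2-fold (0.63 log units) apart, beyond the scatter of two such steps. These two pairs do not show why the steps part, nor whether the place of the group, ortho to a large group in compound 4, accounts for the gap, and they say nothing about how the exchange would behave on any further core.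

The compounds shown leave open how a nitrile, a methoxy group or a plain chlorine on the same aryl group would compare with trifluoromethyl and trifluoromethoxy. They also leave open whether the exchange would behave the same way with a sulfone in place of the sulfur, or with the hydroxyl group replaced by an amine.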